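The source may report more compounds than this note shows. Statements on the series, on what has been measured and on what is new or still open speak of the compounds shown alone.

Of the compounds shown here, three have been measured in a functional assay on HeLa cells (Homo sapiens) for cytotoxicity, read by MTT assay, with a stated time of 24 h; a lower number here means a stronger inhibitor, a higher number a weaker inhibitor. Compound 1 `O=C(NC(=S)Nc1nc2cc(Br)ccc2s1)N1CCOCC1` and compound 2 `O=C(NC(=S)Nc1nc2ccccc2s1)N1CCOCC1` share one core, while compound 3 `O=C(NC(=S)Nc1nc2cc(Br)ccc2s1)c1ccc([N+](=O)[O-])cc1` carries a different part on the thiourea; the difference between the two cores is not broken down here. In this assay compound 1 gives 38900 nM, compound 2 gives 51800 nM, and compound 3 gives 56500 nM. All three numbers lie within the usual scatter of one another, so no order among them can be read from these data.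

Compound 2 differs from compound 1 by a single change, (hydrogen in place of bromo on an aromatic carbon). That change made a 1.3-fold higher number from compound 1 to compound 2 (0.12 log units; within the scatter).

Compound 4 `O=C(NC(=S)Nc1nc2ccccc2s1)c1ccc([N+](=O)[O-])cc1`, not yet measured, differs from compound 3 by the same change, (hydrogen in place of bromo on an aromatic carbon). Among these compounds the change occurs twice, once with a measured outcome and once still open. Because a 1.3-fold higher number from compound 1 to compound 2 (0.12 log units; within the scatter) was small, a step of similar size is expected here, a 1.2-fold higher number from compound 3 to compound 4 (0.09 log units; within the scatter). On that basis compound 4 is estimated to give 70000 nM in this assay, with a likely range from 35000 nM to 140000 nM.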

Compound 4, half-maximal inhibitory concentration: 62600 nM
Compound 4: the middle estimate sits 1.1-fold (0.05 log units) above what was measured; the measured number falls inside the stated range.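

In this assay, hydrogen in place of bromo on the aromatic carbon gives a 1.1-fold higher number from compound 3 to compound 4 (0.04 log units; within the scatter), so on this second core too the swap leaves no difference that can be read. Set beside the earlier case, the two steps agree, and the change carries from one core to the other as a step too small to read: the same change on two cores in this assay, a 1.3-fold higher number (0.12 log units; within the scatter) from compound 1 to compound 2 and a 1.1-fold higher number (0.04 log units; within the scatter) from compound 3 to compound 4, 1.2-fold (0.08 log units) apart, within the scatter of two such steps. This shows only that hydrogen and bromo cannot be told apart at this spot in these two pairs; it does not show that bromo has no effect at all, since a small real effect could hide in the scatter, and two cores say nothing about any others.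

The compounds shown leave open whether a different group on that aromatic carbon, such as an amine, a methoxy group or a carboxylic acid, would give a step beyond the scatter. They also leave open what a longer chain would do in place of the part that differs between the two cores.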